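Compound 1 to compound 4: a side chain swapped

This account rests on a few compounds, and the source may have more. Where it says the series, first, only, none or still open, it means among the compounds named here.

Measured so far in a functional assay on HCT-116 cells (Homo sapiens) for inhibition, read by fluorescence, with a stated time of 48 h; on this read-out higher numbers stand for weaker inhibition of growth and lower numbers for stronger inhibition of growth

- Compound 1 `CC(C)[C@H](N)C(=O)OCCCOC1(c2ccc(Cl)cc2)c2ccccc2C(=O)N1Cc1ccc(Cl)cc1` gives 16000 nM
- Compound 2 `N[C@H](C(=O)OCCCOC1(c2ccc(Cl)cc2)c2ccccc2C(=O)N1Cc1ccccc1)c1ccccc1` gives 14000 nM
- Compound 3 `CC(C)(COC(=O)[C@@H](N)c1ccccc1)COC1(c2ccc(Cl)cc2)c2ccccc2C(=O)N1Cc1ccccc1` gives 15000 nM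

These three values lie within the usual scatter of one another, so compound 1 stands level with compound 2 and compound 3, and they cannot be ranked. Compound 4 `CC(C)(CO)COC1(c2ccc(Cl)cc2)c2ccccc2C(=O)N1Cc1ccc(Cl)cc1` has not yet been measured. It keeps the core of compound 1 but changes one side chain: 1-(hydroxymethyl)-1-methylethyl in place of 2-(((1-amino-2-methylpropyl)carbonyl)oxy)ethyl on a saturated chain carbon bound to an oxygen on a saturated carbon. Here 1-(hydroxymethyl)-1-methylethyl enters in place of 2-(((1-amino-2-methylpropyl)carbonyl)oxy)ethyl on a saturated chain carbon bound to an oxygen on a saturated carbon.

For the measured compounds named here, no measured pair shows this change alone, so the data offer no direct guide. No step beyond the scatter is expected in this assay in either direction. That expectation rests on compound 1 at 16000 nM and compound 2 at 14000 nM and compound 3 at 15000 nM sitting together although their structures differ. The expected step is a 1.1-fold lower number from compound 1 to compound 4 (0.06 log units; within the scatter) and no more than that. For compound 4 the estimated value is 14000 nM with an expected range from 6000 nM to 30000 nM in this measurement.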

Compound 4, concentration for 50% growth inhibition: 50000 nM
Compound 4: the middle estimate sits 3.6-fold (0.55 log units) below what was measured; the measured number lies above the stated range.
By their numbers in this assay, from the lowest: compounds 2, 3 and 1 (each within the scatter of the next); then compound 4.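

In this assay, the swap of 2-(((1-amino-2-methylpropyl)carbonyl)oxy)ethyl for 1-(hydroxymethyl)-1-methylethyl gives a 3.1-fold higher number from compound 1 to compound 4 (0.49 log units; beyond the scatter) and thus weaker inhibition of growth beyond the scatter. For the compounds shown here, this is the first sign that this position is not indifferent to what it carries, since the three earlier compounds could not be ranked against one another. Nothing measured here explains the loss, so the reason for this step remains unknown.

The change removes the amino-bearing ester and also alters the chain to the hydroxyl group, so this one step cannot show which of these differences matters. A plain 3-hydroxypropyl chain on the same core would separate them, while a simple amine or a carboxylic acid at the end of the chain would show what other end groups do here.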